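From pyridin-2-yl to 4-cyclopropylphenyl on the ring nitrogen

The compounds below may be only part of what the source reports. "The series", "measured", "known", "first", "only" and "open" are said of these compounds alone.

Among the measured compounds shown here, in an ADME assay on microsomes from liver (Homo sapiens) for metabolic stability, read by LC-MS, using NADPH, with a stated time of 10 min, tested at 0.1 uM (on this read-out lower numbers stand for slow clearance and higher numbers for fast clearance), compound 3 `O=C(NCCCCc1ccccc1)c1cccc(C2SCC(=O)N2c2ccccn2)c1` gives 412 mL.min-1.g-1, which places it near the low end of the numbers measured so far. Compound 2 `O=C(NCCCCc1ccccc1)c1cccc(C2SCC(=O)N2c2cccc(-c3c[nH]nn3)c2)c1` gives 261 mL.min-1.g-1, and the gap between these two is small: a 1.6-fold higher number from compound 2 to compound 3 (0.20 log units; within the scatter). Compound 4 `O=C(NCCCCc1ccccc1)c1cccc(C2SCC(=O)N2c2ccc(C3CC3)cc2)c1` departs from compound 3 in one place: 4-cyclopropylphenyl in place of pyridin-2-yl on an amide-type nitrogen in a ring, (4-cyclopropylphenyl in place of pyridin-2-yl on an amide-type nitrogen in a ring). For the measured compounds named here, the one measured step at this position involves neither of these two groups, so it offers only a weak guide. A closer guide is compound 1 `CC1SC(c2cccc(C(=O)NCCCCc3ccccc3)c2)N(c2ccc(C3CC3)cc2)C1=O`, which carries the same 4-cyclopropylphenyl on a core that is not quite the same and gives 2010 mL.min-1.g-1. On that evidence, an upward move beyond the scatter is expected, with the estimated step being a 2.9-fold higher number from compound 3 to compound 4 (0.46 log units; beyond the scatter). For compound 4 the estimated value in this assay is 1200 mL.min-1.g-1, with an expected range of 500 mL.min-1.g-1 to 2800 mL.min-1.g-1.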

Compound 4, intrinsic clearance in microsomes: 811 mL.min-1.g-1
The estimate for compound 4 lay 1.5-fold (0.17 log units) above the measured number; the measured number falls inside the stated range.
By their numbers in this assay, from the lowest: compounds 2, 3 and 4 (each within the scatter of the next, the first and the last beyond it); then compound 1.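

In this assay, 4-cyclopropylphenyl in place of pyridin-2-yl on the amide-type nitrogen in a ring gives a step that stays within the scatter (a 2.0-fold higher number from compound 3 to compound 4 (0.29 log units; within the scatter)), so this exchange alone does not clearly separate the two compounds. A different exchange at the same nitrogen does register, with 4-cyclopropylphenyl replacing the larger group that carries a five-membered aromatic ring with 3 hetero atoms (a 3.1-fold higher number from compound 2 to compound 4 (0.49 log units; beyond the scatter)). With 4-cyclopropylphenyl held fixed, the new compound also brings out a second place, since hydrogen in place of methyl on a saturated ring carbon gives a modest step beyond the scatter (a 2.5-fold lower number from compound 1 to compound 4 (0.39 log units; beyond the scatter)).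

Going by these compounds, how a group carrying an amine or a carboxylic acid on this ring nitrogen would read remains open. Nothing measured here says why these numbers differ.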